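The compounds below may be only part of what the source reports. "The series", "measured", "known", "first", "only" and "open" are said of these compounds alone.

In a functional assay on SGC-7901 cells (Homo sapiens) for inhibition, read by MTT assay, with a stated time of 72 h (a lower number here means a stronger inhibitor, a higher number a weaker inhibitor), compound 1 `O=C(NCc1ccc(NC(=O)c2cc(-c3ccccc3)ccc2N2CCCC2)cc1)OCc1cccnc1` gives > 100000 nM, which is a limit and not a number. Compound 2 `O=C(NCc1ccc(NC(=O)c2cccc(F)c2N2CCCC2)cc1)OCc1cccnc1` also gives only a limit, > 100000 nM. Compound 3 `O=C(NCc1ccc(NC(=O)c2ccc(F)cc2N2CCCC2)cc1)OCc1cccnc1` alone reaches a number, 56200 nM. Compound 1 therefore stands at the limit of > 100000 nM in this assay, at which 2 of the 3 values shown sit. Compound 4 `O=C(NCc1ccc(NC(=O)c2cc(C(F)(F)F)ccc2N2CCCC2)cc1)OCc1cccnc1` carries trifluoromethyl in place of phenyl on an aromatic carbon, para to a pyrrolidin-1-yl group: trifluoromethyl in place of phenyl on an aromatic carbon. Among the compounds with values here, no measured pair isolates this change, so only a modest move toward stronger inhibition in this assay is expected, and the nearest guide is compound 3 at 56200 nM. The estimated size of the move is an at least 1.6-fold lower number from compound 1 to compound 4 (0.22 log units; that floor lies within the scatter). For compound 4 the expected value is 60000 nM, within an estimated range of 20000 nM to 150000 nM.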

Compound 4, half-maximal inhibitory concentration: > 100000 nM
Compound 4: a limit, no number; the forecaster's own chance of this, stated with the estimate: 45%; middle value at least 1.6-fold (0.22 log units) from the limit.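

Compound 1 and compound 4 each give only a limit and not a number, and the step between them cannot be read. The compounds shown leave open how trifluoromethyl and phenyl compare in this assay.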